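Fluorine on the methanesulfonamido ring of the thiourea series

The source may report more compounds than this note shows. Statements on the series, on what has been measured and on what is new or still open speak of the compounds shown alone.

Two thioureas sharing the pivalate ester and the tert-butylphenyl end have been measured. In a functional assay on CHO cells for antagonist activity at transient receptor potential cation channel subfamily V member 1 (Rattus norvegicus) (a higher number here means a weaker inhibitor, a lower number a stronger inhibitor), compound 1 `CC(C)(C)C(=O)OCC(CCc1ccc(C(C)(C)C)cc1)NC(=S)NCc1ccc(NS(C)(=O)=O)c(F)c1` gives 152 nM. Compound 2 `CC(C)(C)C(=O)OCC(NC(=S)NCc1ccc(NS(C)(=O)=O)cc1)c1ccc(C(C)(C)C)cc1` differs from it both in the placement of the tert-butylphenyl group and in the absence of the fluorine; in this assay compound 2 gives 940 nM, the higher of the two numbers, and the gap to compound 1 lies beyond the usual scatter. The two compounds differ in more than one place, so the gap cannot be assigned to either change alone.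

Compound 3 `CC(C)(C)C(=O)OCC(NC(=S)NCc1ccc(NS(C)(=O)=O)c(F)c1)c1ccc(C(C)(C)C)cc1` keeps the core of compound 2 and carries one change: fluoro in place of hydrogen on an aromatic carbon. Within the data shown here, no measured pair isolates this change. Among the measured compounds shown here, still, the only fluorinated compound, compound 1 with 152 nM, sits well below compound 2, and on that basis a moderate step toward a lower number in this assay is expected from compound 2 to compound 3, a 2.4-fold lower number from compound 2 to compound 3 (0.37 log units; beyond the scatter), though a result within the scatter would not surprise. For compound 3 the expected value in this assay is 400 nM, with a range from 150 nM to 1000 nM.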

Compound 3, inhibition constant: 213 nM
The estimate for compound 3 lay 1.9-fold (0.27 log units) above the measured number, within the range that was stated.
By their numbers in this assay, from the lowest: compounds 1 and 3 (each within the scatter of the next); then compound 2.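

In this assay the fluoro ortho to a methanesulfonamido group can now be read on its own: a 4.4-fold lower number from compound 2 to compound 3 (0.64 log units; beyond the scatter) is a single-change step that lies beyond the scatter, and it shows that going from 4-(methanesulfonamido)phenyl to 3-fluoro-4-(methanesulfonamido)phenyl matters in this series. With the fluoro in place, the second single-change pair shows a 1.4-fold higher number from compound 1 to compound 3 (0.15 log units; within the scatter) for 4-(tert-butyl)phenyl in place of 2-(4-(tert-butyl)phenyl)ethyl on the chain carbon, so this assay does not separate these two groups among the fluorinated compounds. Nothing measured on these compounds bears on why the fluoro step occurs.

The compounds shown leave open whether the fluoro step carries over to the 2-(4-(tert-butyl)phenyl)ethyl series, for which no unfluorinated partner of compound 1 stands here. Also open, going by these compounds, is whether chloro, methoxy or a hydroxyl at this same ring position would act as the fluoro does, and whether a free hydroxyl could stand in place of the pivalate ester.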